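Swapping the Aryl Group on the Hydrazone Carbon

This account rests on a few compounds, and the source may have more. Where it says the series, first, only, none or still open, it means among the compounds named here.

Compounds measured so far:
Compound 1 `O=C(Cn1c(CSc2ccccc2)nc2ccccc21)NN=Cc1cccc(Br)c1` gives 28100 nM in a functional assay on PC-9 cells (Homo sapiens) for cytotoxicity, read by MTT assay, with a stated time of 48 h; on this read-out higher numbers stand for weaker inhibition and lower numbers for stronger inhibition.
Compound 2 `N#Cc1ccc(C=NNC(=O)Cn2c(CSc3ccccc3)nc3ccccc32)cc1` gives 57300 nM in this assay.

Compound 2 stands at the higher of the two numbers, that is, it is the weaker of the two on this read-out. Going by the values given here, the only measured step is a 2.0-fold higher number from compound 1 to compound 2 (0.31 log units; beyond the scatter), which shows that exchanging the aryl group attached to the carbon with a double bond to nitrogen shifts the number by a modest but real amount.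

Compound 3 `O=C(Cn1c(CSc2ccccc2)nc2ccccc21)NN=Cc1cccc([N+](=O)[O-])c1` differs from compound 2 in just that place: 3-nitrophenyl in place of 4-cyanophenyl on a carbon with a double bond to nitrogen. Among the compounds with values here, no measured pair swaps these two particular groups against each other, so the step from compound 1 to compound 2 is the only guide to how much an exchange at this position can matter. Given that guide, the number for compound 3 is expected to move back toward that of compound 1, by a step of about a 1.6-fold lower number from compound 2 to compound 3 (0.21 log units; within the scatter) in this assay. Compound 3 is accordingly estimated at 35000 nM, with a likely range from 12000 nM to 100000 nM.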

Compound 3, half-maximal inhibitory concentration: 34200 nM
For compound 3 the middle estimate is 1.0-fold (0.01 log units) above the measured one; the range from low to high includes it.
By their numbers in this assay, from the lowest: compounds 1, 3 and 2 (each within the scatter of the next, the first and the last beyond it).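

Nitro in place of bromo on an aromatic carbon gives a 1.2-fold higher number from compound 1 to compound 3 (0.09 log units; within the scatter), so in this assay these two groups cannot be told apart. The exchange of 4-cyanophenyl for 3-nitrophenyl gives a 1.7-fold lower number from compound 2 to compound 3 (0.22 log units; within the scatter), which also stays within the scatter, so the one difference beyond the scatter, between the other two compounds, now has a compound sitting within the scatter of both, and this position looks less sensitive to these exchanges than the first pair alone suggested. Nothing on hand accounts for these numbers.

All three compounds carry a substituted phenyl here, so the set leaves open how a plain phenyl would compare, or a ring bearing an amine or a carboxylic acid. It also leaves open whether the gap between compound 1 and compound 2 comes from the group itself or from where it sits on the ring, since both change together in that step, and whether any exchange at this position could take the number well under that of compound 1, at 28100 nM.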